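Anilide in place of benzylamide on a weak cytotoxic amide

The source may hold more compounds than are shown below. What is called first, only, known or untested is meant among the compounds shown, and "the series" means these compounds.

Compound 1 `C=CC1=C(C(=O)NCc2ccc(C)cc2)C(c2ccc(F)cc2)OC1` was tested in a functional assay on QGY7701 cells (Homo sapiens) for cytotoxicity, read by MTT assay, with a stated time of 24 h (a higher number here means a weaker inhibitor, a lower number a stronger inhibitor), where compound 1 gives 62100 nM. This is the only number shown for the series; the other value is a limit of the assay. Compound 2 `C=CC1=C(C(=O)Nc2ccccc2)C(c2ccc(OC)cc2)OC1` reaches only that limit, reported for compound 2 as > 100000 nM. Compound 2 thus sits at the limit of > 100000 nM in this assay, at which 1 of the 2 values shown sits.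

Compound 3 `C=CC1=C(C(=O)Nc2ccc(C)cc2)C(c2ccc(F)cc2)OC1` differs from compound 1 by 4-methylphenyl in place of 4-methylbenzyl on an amide-type nitrogen. Within the data shown here, no two measured compounds differ in one place, so no measured step shows how large such a change is in this assay. Compound 1 is already weak at 62100 nM, and the one anilide shown, compound 2, gave no number at all. Compound 3 is therefore expected to remain weak, at an estimated 80000 nM, with a range of 30000 nM to 200000 nM. The step of a 1.3-fold higher number from compound 1 to compound 3 (0.11 log units; within the scatter) is expected to stay within the usual scatter, with a fair chance that only a limit is reported.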

Compound 3, half-maximal inhibitory concentration: 59200 nM
Estimate against measurement, compound 3: 1.4-fold (0.13 log units) above; the range from low to high includes it.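

Among these compounds, with 4-methylphenyl in place of 4-methylbenzyl on the amide-type nitrogen, this assay gives a 1.0-fold lower number from compound 1 to compound 3 (0.02 log units; within the scatter), the first step that changes one place only. At this position the benzylamide and the anilide cannot be told apart in this read-out, and both compounds remain weak. Nothing shown gives a reason for this result.

The compounds shown leave open whether any group on this nitrogen can move the number beyond the scatter, such as a longer chain like phenylethyl, or a carboxylic acid or an amine in place of the methyl on the ring. They also leave open how much the rest of the shared core contributes, as it is the same in compound 1 and compound 3.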